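This account rests on a few compounds, and the source may have more. Where it says the series, first, only, none or still open, it means among the compounds named here.

Compound 1 `O=[N+]([O-])c1cc(C(F)(F)F)cc([N+](=O)[O-])c1Oc1ccccc1/C=N\OCc1ccccc1` gives 1330 nM here
Compound 2 `O=[N+]([O-])c1cc(C(F)(F)F)cc([N+](=O)[O-])c1Oc1ccccc1/C=N\OCc1ccccc1F` gives 680 nM here
Compound 3 `O=[N+]([O-])c1cc(C(F)(F)F)cc([N+](=O)[O-])c1Oc1ccccc1/C=N/OCc1ccccc1Cl` gives 1170 nM here

These values come from a functional assay on HepG2 cells (Homo sapiens) for antiproliferative activity, read by MTT assay, with a stated time of 48 h (on this read-out higher numbers stand for weaker inhibition and lower numbers for stronger inhibition), and compound 1 cannot be told apart from the other two, since all three lie within the scatter of one another, as does the gap shown by a 1.7-fold higher number from compound 2 to compound 3 (0.24 log units; within the scatter) between the two halogen compounds.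

Compound 4 `O=[N+]([O-])c1cc(C(F)(F)F)cc([N+](=O)[O-])c1Oc1ccc(Cl)cc1/C=N\OCc1ccccc1` is compound 1 with a single change, chloro in place of hydrogen on an aromatic carbon, meta to a large group and para to a large group.

The closest guides are two halogen steps, a 2.0-fold lower number from compound 1 to compound 2 (0.29 log units; within the scatter) and a 1.1-fold lower number from compound 1 to compound 3 (0.06 log units; within the scatter). Both are small, but compound 2 and compound 3 carry their halogen on a different ring from compound 4, so they guide only loosely. No change beyond the scatter is therefore expected in this assay.

The expected step is a 1.4-fold lower number from compound 1 to compound 4 (0.15 log units; within the scatter), a modest one.

For compound 4 the estimated value is 950 nM, with an expected range from 400 nM to 2200 nM.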

Compound 4, half-maximal inhibitory concentration: 1790 nM
Compound 4: the middle estimate sits 1.9-fold (0.28 log units) below what was measured; the range from low to high includes it.
By their numbers in this assay, from the lowest: compounds 2, 3, 1 and 4 (each within the scatter of the next, the first and the last beyond it).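

On this aromatic carbon, meta to a large group and para to a large group, chloro in place of hydrogen gives a 1.3-fold higher number from compound 1 to compound 4 (0.13 log units; within the scatter) in this assay. For the compounds shown here, the earlier compounds carry their halogen on a different ring, so this is the first sign that the position can hold a chlorine atom with no change that stands clear of the scatter. Nothing available here explains the size of this step.

One substituent cannot show whether the position stays as permissive with other groups, such as a methoxy group, an amine or a carboxylic acid. On these data alone, it also remains open whether chloro here would give a similar step in a compound that already has a halogen on the other ring.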